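Swapping the Amide Tail for a Hydroxy Group

The source may report more compounds than this note shows. Statements on the series, on what has been measured and on what is new or still open speak of the compounds shown alone.

Of the compounds shown here, three sharing one core have been tested in an ADME assay on Vero cells (Chlorocebus sabaeus) for cytotoxicity; a lower number here means that less compound is tolerated, a higher number that more compound is tolerated. Compound 1 `O=C(CN1CCCCC1)Nc1ccc(-c2nc3cc(C(F)(F)F)ccc3[nH]2)cc1` gives 31000 nM, compound 2 `Fc1ccc(-c2nc3cc(C(F)(F)F)ccc3[nH]2)cc1` gives 60000 nM, and compound 3 `O=C(CCl)Nc1ccc(-c2nc3cc(C(F)(F)F)ccc3[nH]2)cc1` gives 35000 nM. Compound 3 sits within the usual scatter of both neighbours: a 1.1-fold higher number from compound 1 to compound 3 (0.05 log units; within the scatter) and a 1.7-fold lower number from compound 2 to compound 3 (0.23 log units; within the scatter). The three numbers therefore cannot be told apart.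

Compound 4 `Oc1ccc(-c2nc3cc(C(F)(F)F)ccc3[nH]2)cc1` is the next step from compound 3: hydroxy in place of ((chloromethyl)carbonyl)amino on an aromatic carbon. The step from compound 2 to compound 3 bears most directly on this, since it also exchanges a small group for the ((chloromethyl)carbonyl)amino group at the same aromatic carbon and stayed within the scatter. The step from compound 1 to compound 3, which reshaped the tail, stayed within the scatter as well. Neither change at this position moved the readout, so no step beyond the scatter is expected for compound 4, giving a 1.1-fold higher number from compound 3 to compound 4 (0.06 log units; within the scatter). Compound 4 is thus estimated at 40000 nM, with a range from 15000 nM to 100000 nM.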

Compound 4, half-maximal cytotoxic concentration: > 100000 nM
Compound 4: only a limit was reported; the forecaster's own chance of this, stated with the estimate: 15%; at least 2.5-fold (0.39 log units) between middle value and limit.
By their numbers in this assay, from the lowest: compounds 1, 3 and 2 (each within the scatter of the next). At a limit, above all of these: compound 4.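

Going by these compounds alone, at this aromatic carbon, para to a large group, the choice of group can move the read-out in this assay: hydroxy in place of ((chloromethyl)carbonyl)amino gives the first step beyond the scatter (an at least 2.8-fold higher number from compound 3 to compound 4 (0.45 log units; beyond the scatter)). The reading for compound 4 is a limit of the assay, not a number: the limit of > 100000 nM in this assay, at which 1 of the 4 values shown sits. Hydroxy in place of fluoro at the same carbon gives only a floor within the scatter (an at least 1.6-fold higher number from compound 2 to compound 4 (0.22 log units; that floor lies within the scatter)), so hydroxy is separated from the ((chloromethyl)carbonyl)amino group but not yet from fluoro.

Going by these compounds, the full size of both steps stays open, since each rests on a limit. Also open, on these data alone, is how other groups on this carbon, such as an amine, a carboxylic acid or a methoxy group, would read in this assay.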